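Swapping one aromatic group on a shared core

The source may hold more compounds than are shown below. What is called first, only, known or untested is meant among the compounds shown, and "the series" means these compounds.

- compound 1 `CC(=O)N1CCC(c2cnc(NCc3c(F)ccc4c3CCO4)c3cn[nH]c(=O)c23)CC1`: 207 mL.min-1.g-1
- compound 2 `Cc1ncc(-c2cnc(NCc3c(F)ccc4c3CCO4)c3cn[nH]c(=O)c23)n1C`: 10 mL.min-1.g-1
- compound 3 `CN(C)C(=O)c1cc(-c2cnc(NCc3c(F)ccc4c3CCO4)c3cn[nH]c(=O)c23)n(C)n1`: 21 mL.min-1.g-1

In an ADME assay on microsomes from liver (Homo sapiens) for metabolic stability, read by LC-MS, using NADPH, with stated times of 5 min and 30 min, tested at 1 uM (a higher number here means faster removal of the compound, a lower number slower removal), compound 3 gives 21 mL.min-1.g-1, the second highest of the three numbers. Compound 4 `Cc1ncccc1-c1cnc(NCc2c(F)ccc3c2CCO3)c2cn[nH]c(=O)c12` carries 2-methylpyridin-3-yl in place of 3-(dimethylcarbamoyl)-1-methyl-1H-pyrazol-5-yl on an aromatic carbon. Two large drops came when an aromatic ring group replaced 1-acetylpiperidin-4-yl: a 21-fold lower number from compound 1 to compound 2 (1.32 log units; beyond the scatter) and a 9.9-fold lower number from compound 1 to compound 3 (0.99 log units; beyond the scatter). Exchanging one such group for another moved the number far less: a 2.1-fold higher number from compound 2 to compound 3 (0.32 log units; beyond the scatter). The new group also has an aromatic ring, so a small change is expected, slightly downward and no larger than that last step. The expected result is a 1.4-fold lower number from compound 3 to compound 4 (0.15 log units; within the scatter). For compound 4 the estimate is 15 mL.min-1.g-1, with an expected range from 6 mL.min-1.g-1 to 40 mL.min-1.g-1.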

Compound 4, intrinsic clearance in microsomes: 41 mL.min-1.g-1
The estimate for compound 4 lay 2.7-fold (0.44 log units) below the measured number; the measured number lies above the stated range.
By their numbers in this assay, from the lowest: compound 2; then compounds 3 and 4 (each within the scatter of the next); then compound 1.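

In this assay a six-membered aromatic ring at this position still gives a 5.0-fold lower number from compound 1 to compound 4 (0.70 log units; beyond the scatter) and so the drop from 1-acetylpiperidin-4-yl holds for all three aromatic groups shown, not only the five-membered ones. Among these groups, the change gives a 2.0-fold higher number from compound 3 to compound 4 (0.29 log units; within the scatter) and that step stays within the scatter, while a 4.1-fold higher number from compound 2 to compound 4 (0.61 log units; beyond the scatter) shows that the choice of aromatic group can still matter. On these data alone, whether a plain phenyl ring would behave like 2-methylpyridin-3-yl, or whether an amine on that ring would shift the number, stays open. No measurement shown explains why these groups differ.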